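This account rests on a few compounds, and the source may have more. Where it says the series, first, only, none or still open, it means among the compounds named here.

In a functional assay on HL-60 cells (Homo sapiens) for antiproliferative activity, read by MTT assay (on this read-out lower numbers stand for stronger inhibition and higher numbers for weaker inhibition), three compounds built on a shared core have been tested. Compound 1 (`C=C[C@@H]1O[C@H](COCc2ccccc2)[C@@H](OCc2ccccc2)[C@H](OCc2ccccc2)[C@H]1O`) gives 11800 nM and compound 2 (`CC(C)(C)C[C@H]1O[C@H](COCc2ccccc2)[C@@H](OCc2ccccc2)[C@H](OCc2ccccc2)[C@H]1O`) gives 12100 nM, so these two lie within the usual scatter of each other. Compound 3 (`CCCC[C@@H]1O[C@H](COCc2ccccc2)[C@@H](OCc2ccccc2)[C@H](OCc2ccccc2)[C@H]1O`) is reported only as "not active" (no number reported), so it has no number to compare. Compound 4 (`CC(C)(C)C[C@@H]1O[C@H](COCc2ccccc2)[C@@H](OCc2ccccc2)[C@H](OCc2ccccc2)[C@H]1O`) has yet to be measured. The structural change is tert-butyl in place of propyl on a saturated chain carbon bound to a saturated ring carbon, which also reads as butyl to neopentyl. A step towards stronger inhibition is expected, though its size cannot be stated without a number for compound 3. The best guide is compound 2, which also carries neopentyl and gives 12100 nM. Compound 4 is estimated at 14000 nM, with an expected range of 6000 nM to 35000 nM.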

Compound 4, half-maximal inhibitory concentration: "not active" (no number reported)
The entry for compound 4 holds no number, so the estimate cannot be set against anything.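

Going by these compounds alone, compound 3 and compound 4 are both reported only as not active in this assay, so no step between them can be read. Left open is how far compound 4 lies from compound 2, which gives 12100 nM, and what the drawn configuration contributes, the one point to go on being: the fact that compounds 2 and 4 differ only in the configuration as drawn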